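The compounds below may be only part of what the source reports. "The series", "measured", "known", "first", "only" and "open" are said of these compounds alone.

Measured in an ADME assay on HEK293 cells (Homo sapiens) for cytotoxicity, read by MTT assay, with a stated time of 72 h; a higher number here means a weaker inhibitor, a lower number a stronger inhibitor:
compound 1 `COc1ccc(C2=C(c3cc(OC)c(OC)c(OC)c3)C(=O)CC2O[SiH2]C(C)(C)C)cc1`: > 100 ug/mL (a limit)
compound 2 `COc1ccc(C2=C(c3cc(OC)c(OC)c(OC)c3)CC(O)C2=O)cc1[N+](=O)[O-]`: > 100 ug/mL (a limit)

Compound 1 gives no number in this assay, only the limit > 100 ug/mL. The two measured compounds both stand at the limit of > 100 ug/mL in this assay, at which 2 of the 2 values shown sit. Compound 3 `COC(=O)c1cc(C2=C(c3cc(OC)c(OC)c(OC)c3)C(=O)CC2O[SiH2]C(C)(C)C)ccc1OC` differs from compound 1 by methoxycarbonyl in place of hydrogen on an aromatic carbon, with methoxycarbonyl in place of hydrogen on an aromatic carbon, ortho to a methoxy group. Within the data shown here, no measured step bears on this change, so no move beyond the scatter is expected. The expected step is a number no higher from compound 1 to compound 3 (the limit leaves the size open). For compound 3 the estimate is 100 ug/mL, with an expected range from 50 ug/mL to 200 ug/mL, and a reported limit is the likeliest outcome.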

Compound 3, half-maximal inhibitory concentration: > 100 ug/mL
Compound 3 was reported as a limit (the forecaster's own chance of this, stated with the estimate: 80%); the middle value sits exactly at the limit.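

No step can be read from compound 1 to compound 3, as both values are limits: the limit of > 100 ug/mL in this assay, at which 3 of the 3 values shown sit.
In this assay the compounds shown leave open whether methoxycarbonyl in place of hydrogen on an aromatic carbon changes the read-out at all.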